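The source may report more compounds than this note shows. Statements on the series, on what has been measured and on what is new or still open speak of the compounds shown alone.

In a functional assay on A549 cells (Homo sapiens) for antiproliferative activity, read by MTT assay, with a stated time of 72 h (a higher number here means a weaker inhibitor, a lower number a stronger inhibitor), the measured compounds are:
compound 1 `CNc1nc(-c2cc(OC)c(OC)c(OC)c2)c(-c2ccc(OC)cc2)s1` with 138 nM
compound 2 `CCOc1ccc(-c2sc(NC)nc2-c2cc(OC)c(OC)c(OC)c2)cc1` with 38.6 nM

Compound 2 holds the lower of the two numbers. Going by the values given here, the one measured step is a 3.6-fold lower number from compound 1 to compound 2 (0.55 log units; beyond the scatter) and is modest, though beyond the scatter. Compound 3 `CCOc1ccc(-c2sc(C)nc2-c2cc(OC)c(OC)c(OC)c2)cc1` carries a new change, methyl in place of methylamino on an aromatic carbon with methyl in place of methylamino on an aromatic carbon. The measured step lies at the 4-ethoxyphenyl group, so it sets no size for this change. A larger step toward a higher number in this assay is nevertheless expected, on thin evidence. The estimated value for compound 3 is 600 nM with an expected range from 100 nM to 4000 nM in this estimate. The estimate means an expected 16-fold higher number from compound 2 to compound 3 (1.19 log units; beyond the scatter) for this change.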

Compound 3, half-maximal inhibitory concentration: 3320 nM
For compound 3 the middle estimate is 5.5-fold (0.74 log units) below the measured one; the measured number falls inside the stated range.
By their numbers in this assay, from the lowest: compound 2; then compound 1; then compound 3.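

In this assay, methyl in place of methylamino, on the ring carbon next to the ring nitrogen and the ring sulfur, gives an 86-fold higher number from compound 2 to compound 3 (1.93 log units; beyond the scatter). This is far larger than a 3.6-fold lower number from compound 1 to compound 2 (0.55 log units; beyond the scatter) at the 4-ethoxyphenyl group, so among these compounds the methylamino position weighs more heavily on the number. No measurement given here accounts for the size of this step.

The compounds shown leave open whether a primary amine or ethylamino at this position would keep the number near that of compound 2. They also leave open whether the same change would cost as much on the core of compound 1.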